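Sulfonyl series: amide in place of the cyclic sulfonamide

The compounds below may be only part of what the source reports. "The series", "measured", "known", "first", "only" and "open" are said of these compounds alone.

Going by the values given here, compound 2 `O=S(=O)(c1cccc(F)c1)c1ccc2c(c1)CCC[C@H]2CN1CCCS1(=O)=O` stands at the top of the two numbers measured so far: in an assay on isolated protein for displacement of a labelled ligand from 5-hydroxytryptamine receptor 6 (Homo sapiens) (on this read-out lower numbers stand for stronger inhibition and higher numbers for weaker inhibition), compound 2 gives 31.6 nM, while compound 1 `N#Cc1cccc(S(=O)(=O)c2ccc3c(c2)CCC[C@H]3C=N)c1` gives 0.501 nM, a gap well beyond the scatter. The two differ in more than one place, so no single step can be read from them.

Compound 3 `CC(C)(C)C(=O)NC[C@@H]1CCCc2cc(S(=O)(=O)c3cccc(F)c3)ccc21` is the next entry and is not yet measured. Relative to compound 2, the change is a group of 7 heavy atoms (5 carbon, 1 nitrogen, 1 oxygen; no ring) in place of a group of 7 heavy atoms (3 carbon, 1 nitrogen, 2 oxygen, 1 sulfur; one five-membered non-aromatic ring with 2 hetero atoms), on a saturated chain carbon bound to a saturated ring carbon. Among the compounds with values here, the group that leaves and the ((tert-butyl)carbonyl)amino group that enters carry the same count of heavy atoms, and no measured pair isolates a change of this kind, so the expectation rests on compound 2 alone.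

In this assay the expected step is a 1.1-fold lower number from compound 2 to compound 3 (0.05 log units; within the scatter), that is, none beyond the scatter in either direction. Compound 3 is accordingly estimated at 28 nM in this assay, within a range from 6 nM to 130 nM. Within the data shown here, the range is wide because compound 2 gives only the single anchor 31.6 nM and the entering group has no measured precedent here.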

Compound 3, inhibition constant: 3.98 nM
Compound 3: middle estimate off by 7.0-fold (0.85 log units), on the high side; measured number below the stated range.
By their numbers in this assay, from the lowest: compound 1; then compound 3; then compound 2.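

On the saturated chain carbon bound to a saturated ring carbon, the number in this assay depends on more than the heavy-atom count: at an equal count, placing the ((tert-butyl)carbonyl)amino group there gives a 7.9-fold lower number from compound 2 to compound 3 (0.90 log units; beyond the scatter), a step beyond the scatter. Going by these compounds alone, this is the first single-place step, and it shows that this position tolerates an open group with no ring in place of the five-membered non-aromatic ring, with a lower number as the outcome. The swap alters several features at once, including the ring, the sulfur, and the change from 0 hydrogen-bond donors to 1 hydrogen-bond donor, and no measurement on hand ties the step to any one of them.

From the compounds shown here alone, it remains open whether the step follows the tert-butyl part or the carbonylamino link, which an acetylamino, a cyclopropylcarbonylamino or an open-chain methanesulfonylamino group at this position would help to separate. Compound 1 differs from compound 3 in more than one place, so how its group at this position ranks against the ((tert-butyl)carbonyl)amino group also stays unresolved.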